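Ring Size and Acid Placement on the Amine Tail

The source may hold more compounds than are shown below. What is called first, only, known or untested is meant among the compounds shown, and "the series" means these compounds.

Measured so far:
compound 1, `COc1ccc(/C=C\c2cc(OC)c(OC)c(OC)c2)cc1OCc1ccc(CN2CC[C@H](C(=O)O)C2)cc1`, > 10000 nM
compound 2, `COc1ccc(/C=C\c2cc(OC)c(OC)c(OC)c2)cc1OCc1ccc(CN[C@H](C(=O)O)[C@H](C)O)cc1`, > 10000 nM
compound 3, `COc1ccc(/C=C\c2cc(OC)c(OC)c(OC)c2)cc1OCc1ccc(CN2CC(C(=O)O)C2)cc1`, 6500 nM

All three compounds share one core and differ only in the group carried on a saturated chain carbon bound to an aromatic carbon. In a functional assay on HeLa cells (Homo sapiens) for antiproliferative activity, read by CCK-8 assay, with a stated time of 48 h (on this read-out lower numbers stand for stronger inhibition and higher numbers for weaker inhibition), compound 1 reaches only a limit, > 10000 nM. In this assay compound 2 likewise reaches only a limit, > 10000 nM. For the measured compounds named here, compound 3 is the one compound with a number, 6500 nM, and so it stands alone among the values shown. The steps of an at least 1.5-fold lower number from compound 1 to compound 3 (0.18 log units; that floor lies within the scatter) and an at least 1.5-fold lower number from compound 2 to compound 3 (0.18 log units; that floor lies within the scatter) are each read against (the limit of > 10000 nM in this assay, at which 2 of the 3 values shown sit), and neither can be sized.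

Compound 4, `COc1ccc(/C=C\c2cc(OC)c(OC)c(OC)c2)cc1OCc1ccc(CN2CCCCC2C(=O)O)cc1`, carries 2-carboxypiperidin-1-yl in place of 3-carboxyazetidin-1-yl on a saturated chain carbon bound to an aromatic carbon. Going by the values given here, no measured step exchanges a four-membered ring for a six-membered one, and none moves the acid from the 3-position of the ring to the 2-position, so the measured steps give only the loose picture that compound 3 sits near the edge of what the assay resolves. The step of a 1.4-fold higher number from compound 3 to compound 4 (0.14 log units; within the scatter) is therefore expected to be small, with a real chance of another limit. Compound 4 is estimated at 9000 nM, within 3000 nM to 30000 nM.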

Compound 4, half-maximal inhibitory concentration: 14200 nM
For compound 4 the middle estimate is 1.6-fold (0.20 log units) below the measured one; the measured number falls inside the stated range.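

In this assay, replacing 3-carboxyazetidin-1-yl with 2-carboxypiperidin-1-yl on a saturated chain carbon bound to an aromatic carbon gives a 2.2-fold higher number from compound 3 to compound 4 (0.34 log units; beyond the scatter). For the compounds shown here, this is the first step at this position whose size can be read, and it shows that the six-membered ring with its acid in the 2-carboxy arrangement gives a weaker result than the four-membered ring with its 3-carboxy arrangement, though the gap is a modest one. The steps to compound 4 from compound 1 and from compound 2 cannot be read, because each of those compounds reaches only a limit, so compound 4 cannot be ranked against them: the limit of > 10000 nM in this assay, at which 2 of the 4 values shown sit.

Ring size and the place of the acid change together in the one readable step, so the compounds shown cannot say how much of it belongs to either change. They also leave open whether the carboxylic acid itself matters on this tail, a question that a methyl ester or a primary amide on the four-membered ring would address.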